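The compounds below may be only part of what the source reports. "The series", "measured", "known", "first", "only" and "open" are said of these compounds alone.

Of the compounds shown here, two have numbers so far. In a functional assay on A2780/CDDP cells (Homo sapiens) for antiproliferative activity, read by MTT assay, with a stated time of 48 h (on this read-out lower numbers stand for stronger inhibition and higher numbers for weaker inhibition), compound 1 `Cc1cc(=O)oc2cc(Sc3cccc(Cl)n3)ccc12` gives 1000 nM. Compound 2 `O=c1ccc2ccc(Oc3no[n+]([O-])c3S(=O)(=O)c3ccccc3)cc2o1` gives 3440 nM in this assay, the highest of the two numbers; its nearest neighbour is compound 1, whose number is lower by a gap that lies beyond the scatter. Among the measured compounds shown here, the two structures differ in more than one place, so no single step is separated out between them. Compound 3 `Cc1cc(=O)oc2cc(Oc3no[n+]([O-])c3S(=O)(=O)c3ccccc3)ccc12` carries the change (methyl in place of hydrogen on an aromatic carbon); the rest of the structure is that of compound 2. For the measured compounds named here, no measured pair isolates this change, so the expectation for compound 3 rests on compound 2 alone. A change of this size is expected to move the number little in this assay: the expected step of a 1.1-fold lower number from compound 2 to compound 3 (0.06 log units; within the scatter) amounts to none beyond the scatter in either direction. Compound 3 is therefore estimated at 3000 nM, with a range from 1400 nM to 6500 nM.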

Compound 3, half-maximal inhibitory concentration: > 3150 nM
Compound 3: only a limit was reported; the forecaster's own chance of this, stated with the estimate: 5%; middle value at least 1.0-fold (0.02 log units) away from the limit.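

In this assay compound 3 gives > 3150 nM, which is a limit and not a number. No step from compound 2 to compound 3 can be read: the limit of > 3150 nM in this assay, at which 1 of the 3 values shown sits.

The compounds shown leave open how far, and in which direction, methyl in place of hydrogen on an aromatic carbon moves the number.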